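A Larger Group on the Saturated Ring of Compound 2

The source may hold more compounds than are shown below. What is called first, only, known or untested is meant among the compounds shown, and "the series" means these compounds.

Measured so far in an assay on CHO-K1 cells for displacement of a labelled ligand from melanin-concentrating hormone receptor 1 (Homo sapiens), read by scintillation proximity assay, with a stated time of 2 h; on this read-out lower numbers stand for stronger inhibition and higher numbers for weaker inhibition:
compound 1 `Cc1ccc(/C=C/C(=O)Nc2ccc3nc(N4CCC(O)(C5CC5)CC4)nc(C)c3c2)cc1` gives 344 nM
compound 2 `Cc1nc(N2CCC(O)CC2)nc2ccc(NC(=O)/C=C/c3ccc(Cl)cc3)cc12` gives 107 nM
compound 3 `Cc1nc(NCCCNS(C)(=O)=O)nc2ccc(NC(=O)/C=C/c3ccc(OC(F)(F)F)cc3)cc12` gives 54 nM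

In this assay compound 2 stands second highest of the three numbers. Its nearest neighbour is compound 3, whose number lies within the scatter of that of compound 2; compound 1 is furthest from it, and that gap lies beyond the scatter. Compound 4 `Cc1nc(N2CCC(N3CCCC3=O)CC2)nc2ccc(NC(=O)/C=C/c3ccc(Cl)cc3)cc12` differs from compound 2 in one place: 2-oxopyrrolidin-1-yl in place of hydroxy on a saturated ring carbon. Among the measured compounds shown here, no measured pair shows this change, so nothing directly tells its size or direction. The step expected from compound 2 to compound 4 is a 1.1-fold higher number from compound 2 to compound 4 (0.05 log units; within the scatter), that is, nothing clearly beyond the scatter. Compound 4 is therefore estimated at 120 nM, with a range from 40 nM to 400 nM.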

Compound 4, half-maximal inhibitory concentration: 74 nM
The estimate for compound 4 lay 1.6-fold (0.21 log units) above the measured number, and the stated range covers the measured number.
By their numbers in this assay, from the lowest: compounds 3, 4 and 2 (each within the scatter of the next); then compound 1.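

In this assay the change gives a 1.4-fold lower number from compound 2 to compound 4 (0.16 log units; within the scatter) even though 2-oxopyrrolidin-1-yl brings 6 heavy atoms and a five-membered ring to a saturated ring carbon that carried only hydroxy. This position therefore accepts a much larger group, and one with no hydrogen-bond donor, without a shift beyond the scatter. Nothing available explains this result.

On these data alone, whether an amine or a carboxylic acid on the same ring carbon would also stay within the scatter of compound 2 remains open.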